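This account rests on a few compounds, and the source may have more. Where it says the series, first, only, none or still open, it means among the compounds named here.

Of the compounds shown here, three built on one shared core have been tested in an assay on HEK293 cells for inhibition of Fatty-acid amide hydrolase 1 (Homo sapiens), read by fluorescence; on this read-out lower numbers stand for stronger inhibition and higher numbers for weaker inhibition. Compound 1 `COc1ccc(-c2ccc3oc(NC4CCCCC4)nc3c2)cc1C` gives 228 nM. Compound 2 `COc1cccc(-c2ccc3oc(N4Cc5ccccc5C4)nc3c2)c1` gives 28 nM, which is the second highest of the three numbers: its nearest neighbour is compound 3, its furthest compound 1. Compound 3 `COCc1ccc(-c2ccc3oc(N4Cc5ccccc5C4)nc3c2)cc1OC` gives 13 nM. Going by the values given here, the only pair differing in one place is the step of a 2.2-fold lower number from compound 2 to compound 3 (0.33 log units; beyond the scatter), a modest move beyond the scatter.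

Compound 4 `COc1cc(-c2ccc3oc(N4Cc5ccccc5C4)nc3c2)ccn1` differs from compound 2 by 2-methoxypyridin-4-yl in place of 3-methoxyphenyl on an aromatic carbon. Among the compounds with values here, no measured step bears directly on exchanging a ring carbon for a ring nitrogen while the methoxy group stays in place; the step from compound 2 to compound 3 concerns a different addition and offers no guide here. The methoxy group and every other part of the molecule remain as in compound 2. Within the data shown here, with no precedent among the measured compounds, the expected step is a 1.3-fold higher number from compound 2 to compound 4 (0.10 log units; within the scatter), a change not expected to go beyond the scatter. For compound 4 the estimated value in this assay is 35 nM, expected to fall between 12 nM and 100 nM.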

Compound 4, half-maximal inhibitory concentration: 10 nM
Beside the measured number, compound 4's estimate is 3.5-fold (0.54 log units) above it, and the stated range ends above it.
By their numbers in this assay, from the lowest: compounds 4 and 3 (each within the scatter of the next); then compound 2; then compound 1.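

In this assay, the exchange of 3-methoxyphenyl for 2-methoxypyridin-4-yl gives a 2.8-fold lower number from compound 2 to compound 4 (0.45 log units; beyond the scatter), so putting a ring nitrogen into this aromatic ring, and not only adding a group to it as in compound 3, can shift the number beyond the scatter. The two groups have the same count of heavy atoms, while the entering one has 2 hydrogen-bond acceptors in place of 1, so the step comes from a swap within the ring and not from a larger group. Going by these compounds alone, nothing measured so far accounts for the lower number.

Going by these compounds, it remains open whether the step depends on the methoxy group or on where the ring nitrogen sits. A pyridine ring carrying an amine or a fluorine instead of methoxy, or a pyrimidine ring with a second ring nitrogen, would separate these possibilities.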